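Nitro in place of methyl on compound 3

This account rests on a few compounds, and the source may have more. Where it says the series, first, only, none or still open, it means among the compounds named here.

In an ADME assay on HUVEC cells (Homo sapiens) for cytotoxicity, read by MTT assay, with a stated time of 24 h (a lower number here means that less compound is tolerated, a higher number that more compound is tolerated), compound 3 `Cc1ccc(/C=C/c2nnc(-c3ccc4c(c3)OCCO4)o2)cc1` gives 265000 nM. That value lies within the scatter of compound 1 `Brc1cccc(/C=C/c2nnc(-c3ccc4c(c3)OCCO4)o2)c1` at 322000 nM and of compound 2 `O=[N+]([O-])c1ccccc1/C=C/c1nnc(-c2ccc3c(c2)OCCO3)o1` at 323000 nM, so the three cannot be told apart on these numbers.

Compound 4 `O=[N+]([O-])c1ccc(/C=C/c2nnc(-c3ccc4c(c3)OCCO4)o2)cc1` differs from compound 3 by one change, nitro in place of methyl on an aromatic carbon, para to a large group.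

Within the data shown here, the only measured step that bears on this change is a 1.2-fold lower number from compound 1 to compound 3 (0.08 log units; within the scatter), which stays within the scatter and also concerns the same ring. Compound 2 already carries a nitro group on that ring, at another place, and its 323000 nM sits with the other two values. Neither observation points to a real shift, so no step beyond the scatter is expected. The expected size is a 1.1-fold higher number from compound 3 to compound 4 (0.04 log units; within the scatter). For compound 4 the estimated value is 290000 nM, with an expected range of 140000 nM to 520000 nM.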

Compound 4, half-maximal cytotoxic concentration: 299000 nM
Compound 4: the middle estimate sits 1.0-fold (0.01 log units) below what was measured; low and high end bracket the measured number.
By their numbers in this assay, from the lowest: compounds 3, 4, 1 and 2 (each within the scatter of the next).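

In this assay the step of a 1.1-fold higher number from compound 3 to compound 4 (0.05 log units; within the scatter) stays within the scatter, so nitro and methyl cannot be told apart on an aromatic carbon para to a large group. Among these compounds, this is the first direct reading at this position, and it holds although nitro brings three heavy atoms and two hydrogen-bond acceptors where methyl had one heavy atom and none. Compound 4 at 299000 nM also cannot be told apart from compound 2 at 323000 nM, which carries its nitro group at another place on that ring.

No evidence shown here bears on this result. Going by these compounds, whether an amine, a carboxylic acid or a longer chain at this position would give a step beyond the scatter remains open.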